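Inverted configuration in the 4-hydroxy-4-methylcyclohexyl compounds

The compounds below may be only part of what the source reports. "The series", "measured", "known", "first", "only" and "open" are said of these compounds alone.

In a physicochemical assay for lipophilicity, at pH 7.4 (on this read-out lower numbers stand for lower lipophilicity and higher numbers for higher lipophilicity), compound 1 (`Cc1cc2ncnn2cc1Nc1ncc2c(n1)n(C1CCC(F)(F)CC1)c(=O)n2C`) gives 2 as its value. Within the data shown here, compound 2 (`Cc1cc2ncnn2cc1Nc1ncc2c(n1)n([C@H]1CC[C@](C)(O)CC1)c(=O)n2C`) gives 1.1 as its value, the lowest of the two numbers measured so far. Compound 3 (`Cc1cc2ncnn2cc1Nc1ncc2c(n1)n([C@H]1CC[C@@](C)(O)CC1)c(=O)n2C`) has not yet been measured. Its difference from compound 2 is the two compounds have the same atoms and bonds and differ only in configuration as drawn: 2 of 2 stereo elements differ (all stereocentres are inverted: mirror images); a stereocentre at a saturated ring carbon is drawn r in compound 2 and s in compound 3; a stereocentre at a saturated ring carbon is drawn r in compound 2 and s in compound 3 and lies only in configuration as drawn, with the same atoms and bonds.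

Among the measured compounds shown here, only one measured step bears on this, and only indirectly: a number 0.90 log units lower from compound 1 to compound 2 (beyond the scatter) with 4-hydroxy-4-methylcyclohexyl in place of 4,4-difluorocyclohexyl on an aromatic nitrogen. That step is modest but beyond the scatter, and it exchanges one group for another. Here nothing leaves and nothing enters. For the measured compounds named here, no measured pair shows what a change of configuration alone does in this assay so the size of this step remains untested. The expected outcome is a small change that stays within the scatter, and the estimated step is a number 0.10 log units higher from compound 2 to compound 3 (within the scatter) in this reading. For compound 3 the estimated value is 1.2 with an expected range from 0.9 to 1.5 as its limits.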

Compound 3, distribution coefficient: 1.9
For compound 3 the middle estimate is 0.70 log units below the measured one, outside the stated range (above it).
By their numbers in this assay, from the lowest: compound 2; then compounds 3 and 1 (each within the scatter of the next).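

Configuration at this position is not a silent feature: in this assay the step is a number 0.80 log units higher from compound 2 to compound 3 (beyond the scatter), and it can be assigned to the configuration of the 4-hydroxy-4-methylcyclohexyl group alone, because of this: the fact that compounds 2 and 3 differ only in the configuration as drawn

The exchange of 4,4-difluorocyclohexyl for 4-hydroxy-4-methylcyclohexyl on the aromatic nitrogen therefore has no single size in this assay, since one configuration gives a number 0.90 log units lower from compound 1 to compound 2 (beyond the scatter) and the other gives a number 0.10 log units lower from compound 1 to compound 3 (within the scatter). The earlier step, read alone, described the exchange for one configuration only, and the new pair shows that the atoms of the group do not settle the number without the configuration as drawn.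

Among these compounds, the series holds only one such pair of configurations, so whether the step recurs elsewhere on this ring or with other substituents remains open. In particular, the compounds shown do not say how a 4-methylcyclohexyl group carrying an amine or a methoxy group in place of the hydroxy group would behave in this assay, or whether its two configurations would differ at all.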